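Replacing the aryl ether head group in the diphenylmethylpiperidine series

This account rests on a few compounds, and the source may have more. Where it says the series, first, only, none or still open, it means among the compounds named here.

Compound 1 `COc1cc(C(C)=O)ccc1OCCCN1CCC(C(c2ccc(F)cc2)c2ccc(F)cc2)CC1` gives 1.59 nM in a functional assay (aorta) with Oryctolagus cuniculus as the target (a lower number here means tighter binding, a higher number weaker binding), the second highest of the three numbers; compound 3 `COc1cc(C(C)=O)ccc1OCCCN1CCC(C(c2ccc(F)cc2)c2ccc(F)c(F)c2)CC1` gives 1.26 nM, with a 1.3-fold lower number from compound 1 to compound 3 (0.10 log units; within the scatter), and compound 2 `COc1cc(C(C)=O)ccc1OCCCN1CCC(C(c2ccccc2)c2ccc(F)cc2)CC1` gives 6.31 nM, with a 4.0-fold higher number from compound 1 to compound 2 (0.60 log units; beyond the scatter). Compound 4 `Fc1ccc(OCCCN2CCC(C(c3ccc(F)cc3)c3ccc(F)cc3)CC2)cc1` differs from compound 1 by 4-fluorophenyl in place of 4-acetyl-2-methoxyphenyl on an oxygen on a saturated carbon. Every measured step concerns fluorine on the two aromatic rings of the diphenylmethyl group, so none bears on the head group, and the series gives no anchor for this change beyond the value of compound 1. A step with two hydrogen-bond acceptors leaving and none entering is wider than any measured here, so a weaker result is expected, with a 5.0-fold higher number from compound 1 to compound 4 (0.70 log units; beyond the scatter). Compound 4 is estimated at 8 nM, within 1.5 nM to 50 nM.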

Compound 4, dissociation constant: 1.26 nM
Compound 4: the middle estimate sits 6.3-fold (0.80 log units) above what was measured; the whole stated range lies above it.
By their numbers in this assay, from the lowest: compounds 3, 4 and 1 (each within the scatter of the next); then compound 2.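

In this assay, the move from 4-acetyl-2-methoxyphenyl to 4-fluorophenyl on the oxygen reads a 1.3-fold lower number from compound 1 to compound 4 (0.10 log units; within the scatter), so this wide change leaves the number within the scatter. On the core of compound 1, then, the head group can lose its carbonyl, its methoxy and all its hydrogen-bond acceptors without a readable change in this assay. Nothing at hand explains this tolerance.

Still open, going by these compounds, is whether the fluoro of 4-fluorophenyl contributes, which a plain phenyl on the same oxygen would test. Also open, on these data alone, is whether a carboxylic acid or an amine on that ring would be tolerated equally.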